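A Phenol Replaces a Methoxy on the Styryl Arm

This account rests on a few compounds, and the source may have more. Where it says the series, first, only, none or still open, it means among the compounds named here.

In a functional assay on HeLa cells (Homo sapiens) for cytotoxicity, read by WST assay, with a stated time of 48 h (a lower number here means a stronger inhibitor, a higher number a weaker inhibitor), compound 2 `COc1ccc(/C=C/C[C@H]2C[C@@H]([C@@H](O)c3ccccc3)CO[C@@H]2c2ccccc2)cc1` gives 8300 nM, the lowest of the three numbers recorded. Compound 3 `COc1ccc(/C=C/C[C@@H]2C[C@@H]([C@@H](O)c3ccc(OC)c(OC)c3)CO[C@H]2c2ccccc2)cc1OC` gives 16100 nM, a value within the scatter of compound 2, so the two cannot be ranked against each other. Compound 1 `COc1cccc([C@H](O)[C@H]2CO[C@H](c3ccc(OC)c(OC)c3)[C@@H](C/C=C/c3ccc(OC)c(OC)c3)C2)c1` gives 21200 nM, and its gap to compound 2 lies beyond the scatter. Compound 4 `Oc1cccc(/C=C/C[C@H]2C[C@@H]([C@@H](O)c3ccccc3)CO[C@@H]2c2ccccc2)c1` has not yet been measured in this assay. It differs from compound 2 in one place: 3-hydroxyphenyl in place of 4-methoxyphenyl on a double-bonded chain carbon bound to a double-bonded chain carbon. No measured pair among these compounds isolates this exchange, so its direction is unknown; a step no larger than the scatter, in either direction, is expected as a 1.0-fold lower number from compound 2 to compound 4 (0.02 log units; within the scatter). Compound 4 is therefore expected to give 8000 nM, within a range from 3000 nM to 20000 nM.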

Compound 4, half-maximal inhibitory concentration: 18600 nM
The estimate for compound 4 lay 2.3-fold (0.37 log units) below the measured number, and the stated range covers the measured number.
By their numbers in this assay, from the lowest: compounds 2, 3, 4 and 1 (each within the scatter of the next, the first and the last beyond it).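

Among the compounds shown here, this is the first pair to isolate a change on a double-bonded chain carbon bound to a double-bonded chain carbon. In this assay, 3-hydroxyphenyl in place of 4-methoxyphenyl gives a 2.2-fold higher number from compound 2 to compound 4 (0.35 log units; beyond the scatter), a modest step that shows the number at this position responds to the aryl group it carries. No evidence at hand accounts for the step.

The exchange alters the group and its location on the ring together, so the compounds shown cannot separate the two. On these data alone, how 4-hydroxyphenyl, 3-methoxyphenyl or 4-aminophenyl would read at this position remains open.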